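The compounds below may be only part of what the source reports. "The series", "measured", "known", "first", "only" and "open" are said of these compounds alone.

Compound 1 `COc1cc2c(Oc3ccc(NC(=O)c4cc(-c5ccccc5F)ccn4)cc3F)ccnc2cc1OCCCN1CCCCC1`: "not determined" (no result reported)
Compound 2 `COc1cc2c(Oc3ccc(NC(=O)c4cc(-c5ccccc5F)ccn4)cc3F)ccnc2cc1OCCCN1CCN(C)CC1`: "not determined" (no result reported)
Compound 3 `COc1cc2c(Oc3ccc(NC(=O)c4cc(-c5ccccc5F)ccn4)cc3F)ccnc2cc1OCCCN1CCCC1`: 610 nM

In a functional assay on U-87MG ATCC cells (Homo sapiens) for cytotoxicity, read by MTT assay, with a stated time of 72 h (a higher number here means a weaker inhibitor, a lower number a stronger inhibitor), compound 1 has no number, and compound 2 has none either. Only compound 3 carries a result, giving 610 nM in this assay. Compound 1 therefore stands nowhere on the numbers; nothing measured places it above or below any other compound.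

Compound 4 `COc1cc2c(Oc3ccc(NC(=O)c4cc(-c5ccccc5)ccn4)cc3F)ccnc2cc1OCCCN1CCCCC1` differs from compound 1 by hydrogen in place of fluoro on an aromatic carbon. Among the compounds with values here, no two measured compounds differ in a single place, so no measured step exists to show how large such a change usually is here. Its direction is open, and a shift no bigger than the usual scatter is as plausible as a real move either way.

Within the data shown here, the only anchor is compound 3 at 610 nM in this assay. Compound 4 is thus expected near 700 nM, with a range from 200 nM to 3000 nM.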

Compound 4, half-maximal inhibitory concentration: 790 nM
For compound 4 the middle estimate is 1.1-fold (0.05 log units) below the measured one, within the range that was stated.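

Compound 1 has no single number to set against compound 4, so no step can be read between them. What the change from 2-fluorophenyl to phenyl does in this assay stays open, and no evidence shown bears on it.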